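This account rests on a few compounds, and the source may have more. Where it says the series, first, only, none or still open, it means among the compounds named here.

Compound 1 `COc1ccc(N(C(=O)CN2C=CN(c3ccccc3)C(=O)C(Cc3n[nH]c4ccccc34)C2=O)C(C)C)cc1` gives 708 nM in a functional assay on CHO cells for agonist activity at Melanocortin receptor 4 (Homo sapiens), read by a luciferase reporter, with a stated time of 4 h; on this read-out lower numbers stand for an effect already at smaller amounts and higher numbers for an effect only at larger amounts of compound. Compound 2 `COc1ccc(N(C(=O)CN2C=CN(c3ccccc3)C(=O)C(Cc3n[nH]c4cc(F)ccc34)C2=O)C(C)C)cc1` carries fluoro in place of hydrogen on an aromatic carbon and in this assay compound 2 gives 355 nM, a step of a 2.0-fold lower number from compound 1 to compound 2 (0.30 log units; within the scatter). Compound 3 `CC(C)N(C(=O)CN1C=CN(c2ccccc2)C(=O)C(Cc2n[nH]c3cc(F)ccc23)C1=O)c1ccccc1` gives 537 nM in this assay, a step of a 1.5-fold higher number from compound 2 to compound 3 (0.18 log units; within the scatter). The difference between the core of compound 1 and the core of compound 3 is not broken down here. Compound 4 `CC(C)N(C(=O)CN1C=CN(c2ccccc2)C(=O)C(Cc2n[nH]c3cc(F)ccc23)C1=O)c1ccc(F)cc1` carries fluoro in place of hydrogen on an aromatic carbon. This is the same kind of change as that from compound 1 to compound 2, but not the same: there the fluoro entered a ring that is part of a fused or bridged system of two rings, meta to a fused ring and para to a fused ring, whereas here it enters a six-membered aromatic ring of carbon only, para to a large group. Because the earlier step of a 2.0-fold lower number from compound 1 to compound 2 (0.30 log units; within the scatter) stayed within the scatter, a comparable outcome is expected for compound 4, an estimated step of a 1.3-fold lower number from compound 3 to compound 4 (0.13 log units; within the scatter). Compound 4 is expected to give about 400 nM in this assay, between 180 nM and 900 nM.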

Compound 4, half-maximal effective concentration: 178 nM
Compound 4: middle estimate off by 2.2-fold (0.35 log units), on the high side, outside the stated range (below it).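

In this assay, fluoro in place of hydrogen on the six-membered aromatic ring of carbon only gives a 3.0-fold lower number from compound 3 to compound 4 (0.48 log units; beyond the scatter), and this step agrees with the earlier one on the other core: the same change on two cores in this assay, a 2.0-fold lower number (0.30 log units; within the scatter) from compound 1 to compound 2 and a 3.0-fold lower number (0.48 log units; beyond the scatter) from compound 3 to compound 4, 1.5-fold (0.18 log units) apart, within the scatter of two such steps. The change thus carries over between these two cores in direction, and no difference in size can be read, but two pairs do not show that it would hold on further cores. Fluoro in place of methoxy gives a 2.0-fold lower number from compound 2 to compound 4 (0.30 log units; within the scatter), so these two groups cannot be told apart here.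

From the compounds shown here alone, it remains open what chloro, trifluoromethyl or an amine would give in the place of this fluoro. Going by these compounds, it also remains open whether the step would hold on a core other than those of compound 1 and compound 3.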